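This account rests on a few compounds, and the source may have more. Where it says the series, first, only, none or still open, it means among the compounds named here.

The measured compounds in this study:

compound 1, `Clc1ccc(OCC2=NCCO2)cc1`, 90%
compound 2, `Cc1ccccc1OCC1=NCCO1`, 100%
compound 3, `Cc1cc(OCC2=NCCO2)ccc1Cl`, 100%

All three were tested in a toxicity assay on the whole organism with Rattus norvegicus as the target, at a dose of 400 mg/kg by the oral route; on this read-out higher numbers stand for a stronger effect at the one dose given and lower numbers for a weaker effect. Compound 1 gives 90%, and compound 3 gives 100%. The two differ in one place, (methyl in place of hydrogen on an aromatic carbon), and this gave a step of a number 10 percentage points higher from compound 1 to compound 3 (within the scatter). Compound 2 gives 100%; how its core differs from the core of compound 1 is not broken down here, and its value and that of compound 3 show no change at the digits printed.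

Compound 4, `Cc1ccc(OCC2=NCCO2)c(C)c1`, has not yet been measured in this assay. It differs from compound 2 by methyl in place of hydrogen on an aromatic carbon. Among the measured compounds shown here, this is the same kind of change as the one from compound 1 to compound 3, though the place differs: there the entering group sat ortho to a chloro group and meta to a group of 7 heavy atoms, here it sits meta to a methyl group and para to a group of 7 heavy atoms. Because compound 2 already gives 100% and the earlier step was a number 10 percentage points higher from compound 1 to compound 3 (within the scatter), the step from compound 2 to compound 4 is expected to be no change at the digits printed from compound 2 to compound 4 (within the scatter). Compound 4 is therefore estimated at 100%, expected to lie between 90% and 100%.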

Compound 4, a percentage reported as activity, at one dose (the size of the read-out at that dose, not a potency): 75%
Beside the measured number, compound 4's estimate is 25 percentage points above it; the whole stated range lies above it.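

In this assay methyl in place of hydrogen on an aromatic carbon gave a number 25 percentage points lower from compound 2 to compound 4 (beyond the scatter) on the core of compound 2, and this step does not match the one seen on the core of compound 1: the same change on two cores in this assay, a number 10 percentage points higher (within the scatter) from compound 1 to compound 3 and a number 25 percentage points lower (beyond the scatter) from compound 2 to compound 4, 35 percentage points apart, beyond the scatter of two such steps. This shows that, within this series, the step measured on one core cannot simply be carried over to another, neither in size nor in direction. It does not show why the two steps part, as the two pairs differ both in the core and in where the methyl enters, and the four compounds cannot separate these two differences.

What the compounds shown leave open is whether a methyl entering the same place on both cores would give matching steps. They also leave open how other groups in that place, such as a methoxy group, an amine or a carboxylic acid, would behave on either core in this assay.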